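This account rests on a few compounds, and the source may have more. Where it says the series, first, only, none or still open, it means among the compounds named here.

Three compounds have been measured in a functional assay on A-375 cells (Homo sapiens) for cytotoxicity, read by CCK-8 assay, with a stated time of 24 h; a higher number here means a weaker inhibitor, a lower number a stronger inhibitor:

Compound 1, `COc1ccccc1Oc1c(N)nc(-c2ccc(Br)cc2)nc1Cl`, gives 63 nM.
Compound 2, `COc1ccccc1Oc1c(N)nc(-c2cccc(I)c2)nc1Cl`, gives 2200 nM.
Compound 3, `COc1ccccc1Oc1c(N)nc(-c2ccc(Br)cc2)nc1OCCO`, gives 10300 nM.

Compound 1 and compound 2 differ by one change, (3-iodophenyl in place of 4-bromophenyl on an aromatic carbon). This change made a large step in this assay: a 35-fold higher number from compound 1 to compound 2 (1.54 log units; beyond the scatter). Compound 3 shares the core of compound 1 but differs from it by 2-hydroxyethoxy in place of chloro on an aromatic carbon, which made an even larger step, a 160-fold higher number from compound 1 to compound 3 (2.21 log units; beyond the scatter).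

Compound 4, `COc1ccccc1Oc1c(N)nc(-c2cccc(I)c2)nc1OCCO`, is not yet measured. It stands to compound 3 as compound 2 stands to compound 1, carrying (3-iodophenyl in place of 4-bromophenyl on an aromatic carbon). The surroundings of the place are not word for word the same: in compound 1 the place is meta to a chloro group and para to a group of 9 heavy atoms, whereas in compound 3 it is meta to a 2-hydroxyethoxy group and para to a 2-methoxyphenoxy group, so this is the same kind of change rather than the same change.

In this assay the step from compound 3 to compound 4 is expected to be a 5.8-fold higher number from compound 3 to compound 4 (0.77 log units; beyond the scatter), weaker than the earlier one because compound 3 already stands at 10300 nM. Compound 4 is therefore estimated at 60000 nM, expected between 15000 nM and 300000 nM.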

Compound 4, half-maximal inhibitory concentration: 1230 nM
The estimate for compound 4 lay 49-fold (1.69 log units) above the measured number, and the stated range ends above it.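

With the 2-hydroxyethoxy group in place, putting 3-iodophenyl in place of 4-bromophenyl gives an 8.4-fold lower number from compound 3 to compound 4 (0.92 log units; beyond the scatter), so this change runs the opposite way to its step on the chloro compounds in this assay: the same change on two cores in this assay, a 35-fold higher number (1.54 log units; beyond the scatter) from compound 1 to compound 2 and an 8.4-fold lower number (0.92 log units; beyond the scatter) from compound 3 to compound 4, 290-fold (2.47 log units) apart, beyond the scatter of two such steps. With the 3-iodophenyl group in place, 2-hydroxyethoxy in place of chloro gives a 1.8-fold lower number from compound 2 to compound 4 (0.25 log units; within the scatter), so that change does not carry over either: the same change on two cores in this assay, a 160-fold higher number (2.21 log units; beyond the scatter) from compound 1 to compound 3 and a 1.8-fold lower number (0.25 log units; within the scatter) from compound 2 to compound 4, 290-fold (2.47 log units) apart, beyond the scatter of two such steps. Across these four compounds, then, the effect of each change depends on the group at the other place, but this shows only that the two changes do not simply add up; it does not show why, or how either change would behave on another core.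

As far as these compounds go, it remains open how an amine or a longer chain ending in a carboxylic acid would behave in place of the chloro or 2-hydroxyethoxy group. From the compounds shown here alone, it is also open whether the halogen or its position on the phenyl ring matters more, which a 3-bromophenyl or 4-iodophenyl group could separate.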